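The source may hold more compounds than are shown below. What is called first, only, known or untested is meant among the compounds shown, and "the series" means these compounds.

Compound 3, `COCc1cc(OC)c(-c2csc3c(N(CCC4CC4)C4CCOCC4)c(OC)nn23)c(OC)c1`, gives 83 nM in an assay on HEK293 cells for displacement of a labelled ligand from corticotropin-releasing factor receptor 1 (Homo sapiens), read by scintillation proximity assay, with a stated time of 2 h (on this read-out lower numbers stand for stronger inhibition and higher numbers for weaker inhibition), and carries the lowest of the three numbers shown, though its steps from compound 1, `CCN(c1c(OC)nn2c(-c3c(OC)cc(COC)cc3OC)csc12)C1CCOCC1`, with 147 nM, and from compound 2, `CCCN(c1c(OC)nn2c(-c3c(OC)cc(COC)cc3OC)csc12)C1CCOCC1`, with 98 nM, both lie within the scatter: a 1.8-fold lower number from compound 1 to compound 3 (0.25 log units; within the scatter) and a 1.2-fold lower number from compound 2 to compound 3 (0.07 log units; within the scatter). Compound 4, `COCc1cc(OC)c(-c2csc3c(N(CC(C)C)C4CCOCC4)c(OC)nn23)c(OC)c1`, differs from compound 3 by isopropyl in place of cyclopropylmethyl on a saturated chain carbon bound to a nitrogen on an aromatic ring. For the measured compounds named here, no measured step touches exactly this position; the nearest ones, a 1.5-fold lower number from compound 1 to compound 2 (0.18 log units; within the scatter) and the two steps already named, all concern the carbon two bonds along from the ring nitrogen and all stay within the scatter. So compound 4 is expected to move little, a 1.3-fold higher number from compound 3 to compound 4 (0.12 log units; within the scatter), and its estimated value is 110 nM, with a range from 55 nM to 220 nM.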

Compound 4, half-maximal inhibitory concentration: 91 nM
Beside the measured number, compound 4's estimate is 1.2-fold (0.08 log units) above it; low and high end bracket the measured number.
By their numbers in this assay, from the lowest: compounds 3, 4, 2 and 1 (each within the scatter of the next).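

In this assay, isopropyl in place of cyclopropylmethyl stays within the scatter, a 1.1-fold higher number from compound 3 to compound 4 (0.04 log units; within the scatter), so at this position the three-membered ring can be absent without a step beyond the scatter. The branched group also stays within the scatter of the unbranched chains, a 1.1-fold lower number from compound 2 to compound 4 (0.03 log units; within the scatter), and a 1.6-fold lower number from compound 1 to compound 4 (0.21 log units; within the scatter). No evidence bears on the reason for this result. From the compounds shown here alone, all four compounds carry only hydrocarbon groups here, so it remains open whether an amine, a carboxylic acid or a longer chain at this place would give a step beyond the scatter.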